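This account rests on a few compounds, and the source may have more. Where it says the series, first, only, none or still open, it means among the compounds named here.

Measured compounds:
compound 1, `NC[C@@H]1CCCc2cc(S(=O)(=O)c3cccc(O)c3)ccc21`, 0.251 nM
compound 2, `NC(=O)CNC[C@@H]1CCCc2cc(S(=O)(=O)c3cccc(F)c3)ccc21`, 0.1 nM

Of the compounds shown here, two that share a core have been measured in an assay on isolated protein for displacement of a labelled ligand from 5-hydroxytryptamine receptor 6 (Homo sapiens); a lower number here means a stronger inhibitor, a higher number a weaker inhibitor. Compound 1, `NC[C@@H]1CCCc2cc(S(=O)(=O)c3cccc(O)c3)ccc21`, gives 0.251 nM, and compound 2, `NC(=O)CNC[C@@H]1CCCc2cc(S(=O)(=O)c3cccc(F)c3)ccc21`, gives 0.1 nM. Of the two, compound 2 has the lower number, and its distance from compound 1 lies beyond the usual scatter of this assay, so compound 2 is the stronger of the pair on the evidence at hand.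

The next compound, compound 3, `CC(C)(C)C(=O)NC[C@@H]1CCCc2cc(S(=O)(=O)c3cccc(F)c3)ccc21`, departs from compound 2 at a single place: (tert-butyl)carbonyl in place of carbamoylmethyl on an amine nitrogen. Within the data shown here, no pair of measured compounds differing at only one place is available, so the size of this step cannot be read from the numbers above.

The account expects compound 3 to give a higher number in this assay than compound 2, a step of a 150-fold higher number from compound 2 to compound 3 (2.18 log units; beyond the scatter), beyond the scatter. On that basis, compound 3 is estimated at 15 nM in this assay, with a likely range from 2 nM to 150 nM.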

Compound 3, inhibition constant: 3.98 nM
Compound 3: middle estimate off by 3.8-fold (0.58 log units), on the high side; the range from low to high includes it.
By their numbers in this assay, from the lowest: compound 2; then compound 1; then compound 3.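

The change at this amine nitrogen, (tert-butyl)carbonyl in place of carbamoylmethyl, gives a 40-fold higher number from compound 2 to compound 3 (1.60 log units; beyond the scatter) in this assay, the first measured sign that activity at this position depends strongly on the substituent. The two groups differ in more than one counted feature: the entering group has 6 heavy atoms and 0 hydrogen-bond donors, while the leaving group has 4 heavy atoms and 1 hydrogen-bond donor, and a single step cannot separate these differences. Nothing measured on these compounds accounts for the rise in the number.

The compounds shown leave open whether the step follows the carbonyl attached directly to the nitrogen or the tert-butyl group itself, a question that an acetyl group or a neopentyl group on the same nitrogen would help to settle. They also leave open how much of the low number of compound 2 depends on the terminal amide of carbamoylmethyl, which could be tested by comparing it with a 2-hydroxyethyl group or a plain ethyl group at this place.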